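The source may hold more compounds than are shown below. What is called first, only, known or untested is meant among the compounds shown, and "the series" means these compounds.

Measured so far:
compound 1 `O=C(Nc1cccc(-c2cnco2)c1)C1CCCN(C(=O)c2cc(C(F)(F)F)cc(C(F)(F)F)c2)C1` — 9%
compound 2 `CS(=O)(=O)Nc1cccc(C(=O)N2CCCC(C(=O)Nc3ccc(Cl)cc3)C2)c1` — 3%

In an ADME assay on PC-3 cells (Homo sapiens) for cytotoxicity, read by WST assay, tested at 100 uM (on this read-out lower numbers stand for less inhibition and higher numbers for more inhibition at the one concentration tested (going by the name of the read-out)), compound 1 gives 9% and compound 2 gives 3%; the two values lie within the usual scatter of each other, so neither stands apart. Compound 3 `Cn1cnnc1-c1cccc(NC(=O)C2CCCN(C(=O)c3cc(C(F)(F)F)cc(C(F)(F)F)c3)C2)c1` differs from compound 1 in one place: 4-methyl-4H-1,2,4-triazol-3-yl in place of 1,3-oxazol-5-yl on an aromatic carbon. Within the data shown here, no measured pair shows this change, so its effect is unknown. With both measured values low in this assay, the expected step is no change at the digits printed from compound 1 to compound 3 (within the scatter), nothing beyond the scatter. Compound 3 is expected to give 9% in this assay, with a range of 0% to 25%.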

Compound 3, a percentage reported as inhibition, at one concentration (the size of the read-out at that concentration, not a potency): 0%
Estimate against measurement, compound 3: 9 percentage points above; low and high end bracket the measured number.
By their numbers in this assay, from the lowest: compounds 3, 2 and 1 (each within the scatter of the next).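

In this assay, 4-methyl-4H-1,2,4-triazol-3-yl in place of 1,3-oxazol-5-yl on this aromatic carbon gives a number 9 percentage points lower from compound 1 to compound 3 (within the scatter) as the first step read at this position. Exchanging one five-membered aromatic ring for another, with one more hetero atom and a methyl group, therefore leaves the read-out within the scatter here. No measurement bears on why this step is small.

From the compounds shown here alone, whether an amine or a carboxylic acid on this aromatic carbon would move the read-out beyond the scatter remains open. So does the outcome of a simple phenyl ring there.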